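A few compounds are considered here, and "the series" means these few. Any claim that something is new, unique, unknown or untested is made for them only; others in the source may bear on it.

Measured so far in an ADME assay on liver for metabolic stability, with Liver microsome (Homo sapiens) as the target, read by LC-MS, using microsomes; a higher number here means faster removal of the compound, a lower number slower removal:
compound 1 `O=C(NCc1cc(Cl)ccc1-n1cnnn1)[C@@H]1C[C@H]2C[C@H]2N1C(=O)[C@H](O)c1cccc(F)c1`: 32 mL.min-1.g-1
compound 2 `O=C(NCc1cc(Cl)ccc1-n1cnnn1)[C@@H]1[C@@H]2C[C@@H]2CN1C(=O)[C@H](O)c1ccccc1F`: < 12 mL.min-1.g-1
compound 3 `CC(C)(C)[C@@H](O)C(=O)N1CSC(C)(C)[C@H]1C(=O)NCc1cc(Cl)ccc1-n1cnnn1`: 360 mL.min-1.g-1

Compound 1 stands lowest of the two numbers in this assay. Compound 3 gives the nearest number, a higher one, and the gap between compound 1 and compound 3 lies beyond the usual scatter of this assay. Compound 2 returns only a limit and no number; it sits at the limit of < 12 mL.min-1.g-1 in this assay, at which 1 of the 3 values shown sits, so its clearance is not resolved.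

The step considered here runs from compound 1 to compound 4 `O=C(NCc1cc(Cl)ccc1-n1cnnn1)[C@@H]1C[C@H]2C[C@H]2N1C(=O)[C@H](O)c1ccccc1`, which has not yet been measured in this assay. The change is hydrogen in place of fluoro on an aromatic carbon.

Going by the values given here, no step between measured compounds matches this change, so the direction must be taken from the change alone. Hydrogen in place of fluoro on an aromatic carbon is a small change, and the step in this assay is expected to stay within the scatter, if anything in the direction of a slightly higher number. The estimated step of a 1.3-fold higher number from compound 1 to compound 4 (0.10 log units; within the scatter) reflects that. Compound 4 is therefore estimated at 40 mL.min-1.g-1 in this assay, with a likely range from 15 mL.min-1.g-1 to 100 mL.min-1.g-1.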

Compound 4, intrinsic clearance in microsomes: < 15 mL.min-1.g-1
Compound 4: no number, only a limit (the forecaster's own chance of this, stated with the estimate: 15%); at least 2.6-fold (0.42 log units) between middle value and limit.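

In this assay, the change from 3-fluorophenyl to phenyl on the core of compound 1 gives an at least 2.1-fold lower number from compound 1 to compound 4 (0.32 log units; beyond the scatter). This is the only pair shown that differs in one place, so it gives the series its sole direct reading of this position: here, a small change on the aromatic ring moves the result beyond the scatter, and the hydrogen gives the lower number. Compound 4 returns a limit and not a number: the limit of < 15 mL.min-1.g-1 in this assay, at which 1 of the 4 values shown sits.

Compound 2 differs from compound 1 in more than one place, so it gives no reading of this change. From the compounds shown here alone, whether an amine, a nitrile or a methoxy group on this aromatic carbon would stay close to compound 4 remains open, as does whether the same step would appear on the core of compound 3.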